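Removing the thiophene chloro in the mGluR5 urea series

The source may report more compounds than this note shows. Statements on the series, on what has been measured and on what is new or still open speak of the compounds shown alone.

Compound 1 `CN1CC(=O)N/C1=N\C(=O)Nc1csc(Cl)c1` is the reference point of this small set. Among the compounds with values here, in an assay on isolated protein for displacement of a labelled ligand from metabotropic glutamate receptor 5 (Homo sapiens) (a higher number here means a weaker inhibitor, a lower number a stronger inhibitor), compound 1 gives 78 nM, and it is the only compound here with a number rather than a limit. Compound 2 `CN1CC(=O)N/C1=N\C(=O)Nc1ccc(Cl)cc1`, the phenyl counterpart, returns only a limit of the assay, > 5000 nM. The shown results thus consist of one measured number and one value at the limit of > 5000 nM in this assay, at which 1 of the 2 values shown sits, so no measured step between two numbers exists and nothing here calibrates the size of a single change.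

Compound 3 `CN1CC(=O)N/C1=N\C(=O)Nc1ccsc1` is the next compound to be measured. It differs from compound 1 by hydrogen in place of chloro on an aromatic carbon. Within the data shown here, no measured pair in this set covers such a change, so the direction rests on the structural change alone: the step from compound 1 to compound 3 is expected to weaken binding beyond the usual scatter, though not to the point of a limit. Compound 3 is therefore estimated at 400 nM, within 100 nM to 2000 nM, which amounts to an expected step of a 5.1-fold higher number from compound 1 to compound 3 (0.71 log units; beyond the scatter).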

Compound 3, half-maximal inhibitory concentration: 700 nM
For compound 3 the middle estimate is 1.8-fold (0.24 log units) below the measured one; the range from low to high includes it.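

Hydrogen in place of chloro on the aromatic carbon next to the ring sulfur gives the only step between two numbers in this set: in this assay there is a 9.0-fold higher number from compound 1 to compound 3 (0.95 log units; beyond the scatter), which places this position among those where the substituent counts for binding and gives the series a single measured calibration of what one change can do. The loss is real but partial, as compound 3 still returns a number, so binding in this series does not depend entirely on the chloro. Compound 2 remains the only compound at a limit: the limit of > 5000 nM in this assay, at which 1 of the 3 values shown sits.

The compounds shown leave open whether a methyl, a bromo or a nitrile on that same carbon would keep the binding of compound 1 or fall back towards that of compound 3, which is what would separate a need for chlorine itself from a need for any group there. One pair also gives no cause for the step and cannot tell whether it would recur at another carbon of the ring or with the shared core altered.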